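Working notes: from the aryl group of compound 2

The compounds below may be only part of what the source reports. "The series", "measured", "known", "first", "only" and "open" are said of these compounds alone.

Compound 1 (`COc1ccc(C(=NNC(=O)NNC(=O)NCCCC(C)Nc2cc(OC)cc3cccnc23)c2ccc(OC)cc2)cc1`) gives 5000 nM
Compound 2 (`COc1cc(NC(C)CCCNC(=O)NNC(=O)Nc2ccc(Cl)c(C(F)(F)F)c2)c2ncccc2c1`) gives 13000 nM

In a functional assay on NCI-H460 cells (Homo sapiens) for inhibition, read by MTT assay, with a stated time of 4 days (on this read-out lower numbers stand for stronger inhibition and higher numbers for weaker inhibition), compound 2 (13000 nM) holds the higher of the two numbers. Compound 1 (5000 nM) stands lower, and the gap lies beyond the scatter.

Compound 3 (`COc1cc(NC(C)CCCNC(=O)NNC(=O)NCCCO)c2ncccc2c1`), not yet measured, carries 3-hydroxypropyl in place of 4-chloro-3-(trifluoromethyl)phenyl on an amide-type nitrogen. For the measured compounds named here, no measured pair isolates this change, so the expectation rests on two values only, and both measured compounds still carry carbon-only aromatic rings in the part that varies. Losing that ring is expected to shift this assay towards weaker inhibition. The expected size is a 2.3-fold higher number from compound 2 to compound 3 (0.36 log units; beyond the scatter) and would lie modestly beyond the scatter. The estimate for compound 3 is 30000 nM (range 9000 nM to 100000 nM).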

Compound 3, half-maximal inhibitory concentration: > 100000 nM
Compound 3 gave a limit, no number; the forecaster's own chance of this, stated with the estimate: 25%; at least 3.3-fold (0.52 log units) between middle value and limit.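

In this assay compound 3 gives > 100000 nM, which is a limit of the assay and not a number. For the compounds shown here, on the amide-type nitrogen, 3-hydroxypropyl in place of 4-chloro-3-(trifluoromethyl)phenyl gives an at least 7.6-fold higher number from compound 2 to compound 3 (0.88 log units; beyond the scatter), the first step that isolates a change in one place, and it shows that inhibition at this position is sensitive to what the nitrogen carries. The true size of this step stays unknown, and only its lower bound can be read: the limit of > 100000 nM in this assay, at which 1 of the 3 values shown sits.

The change removes the carbon-only aromatic ring and brings in the hydroxyl together, and the compounds shown do not separate these two effects. A plain propyl chain or a benzyl group on the same nitrogen would show whether the ring or the hydroxyl governs the loss.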